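Swapping the aryl amide substituent in a transferase probe series

A few compounds are considered here, and "the series" means these few. Any claim that something is new, unique, unknown or untested is made for them only; others in the source may bear on it.

Compound 1 `O=C(CCC(=O)OCCCCCCSc1ccc([N+](=O)[O-])c2nonc12)Nc1ccccc1` gives 700 nM in an assay on isolated protein for inhibition of glutathione S-transferase Mu 2 (Homo sapiens), with a stated time of 10 min; a higher number here means a weaker inhibitor, a lower number a stronger inhibitor.
Compound 2 `O=C(CCC(=O)OCCCCCCSc1ccc([N+](=O)[O-])c2nonc12)Nc1cccc(Cl)c1` gives 1100 nM in this assay.
Compound 3 `COc1ccc(NC(=O)CCC(=O)OCCCCCCSc2ccc([N+](=O)[O-])c3nonc23)cc1OC` gives 360 nM in this assay.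

Compound 3 stands at the low end of the numbers shown: a 1.9-fold lower number from compound 1 to compound 3 (0.29 log units; within the scatter) and a 3.1-fold lower number from compound 2 to compound 3 (0.49 log units; beyond the scatter). Compound 4 `O=C(CCC(=O)OCCCCCCSc1ccc([N+](=O)[O-])c2nonc12)Nc1ccc(F)c(Cl)c1` differs from compound 3 by 3-chloro-4-fluorophenyl in place of 3,4-dimethoxyphenyl on an amide-type nitrogen. The closest guide is the step of a 3.1-fold lower number from compound 2 to compound 3 (0.49 log units; beyond the scatter), which read in reverse points to a higher number for an aryl carrying chloro. The step of a 1.6-fold higher number from compound 1 to compound 2 (0.20 log units; within the scatter) adds a smaller push in the same direction. A modest rise in this assay is therefore expected for compound 4, a 3.3-fold higher number from compound 3 to compound 4 (0.52 log units; beyond the scatter). Compound 4 is estimated at 1200 nM, within a range of 500 nM to 2800 nM.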

Compound 4, half-maximal inhibitory concentration: 470 nM
Compound 4: the middle estimate sits 2.6-fold (0.41 log units) above what was measured; the whole stated range lies above it.
By their numbers in this assay, from the lowest: compounds 3, 4, 1 and 2 (each within the scatter of the next, the first and the last beyond it).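

Placing 3-chloro-4-fluorophenyl on the amide-type nitrogen instead of 3,4-dimethoxyphenyl gives a 1.3-fold higher number from compound 3 to compound 4 (0.12 log units; within the scatter) in this assay, so an aryl carrying chloro need not give a high number. Adding fluoro to the aryl ring that already carries chloro gives a 2.3-fold lower number from compound 2 to compound 4 (0.37 log units; beyond the scatter), the only change here beyond the scatter, while the comparison with phenyl gives a 1.5-fold lower number from compound 1 to compound 4 (0.17 log units; within the scatter) and shows no separation. Nothing available explains the effect of the fluoro.

Still open, as far as these compounds go, is whether fluoro without chloro gives a similar number. An amine or a carboxylic acid on this aryl ring could also behave differently.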